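The compounds below may be only part of what the source reports. "The series", "measured", "known", "first", "only" and "open" are said of these compounds alone.

Compound 2 `Cc1ccc(-c2nc(CN3CCC(C(=O)c4ccc5c(c4)OCCO5)CC3)co2)cc1` was examined in an ADME assay on HEK293 cells (Homo sapiens) for cytotoxicity, read by MTT assay, with a stated time of 36 h; a lower number here means a stronger inhibitor, a higher number a weaker inhibitor. In this assay compound 2 gives only a limit of the assay, > 150 ug/mL. For the measured compounds named here, compound 1 `O=C(c1ccc2c(c1)OCCO2)C1CCN(Cc2coc(-c3ccc(Br)cc3)n2)CC1` is the only other compound measured here, and in this assay compound 1 likewise gives only a limit, > 150 ug/mL. The step that the two limits leave unreadable from compound 1 to compound 2 cannot be read in size or direction, since both values sit at the limit of > 150 ug/mL in this assay, at which 2 of the 2 values shown sit. Compound 3 `O=C(c1ccc2c(c1)OCCO2)C1CCN(Cc2coc(-c3ccco3)n2)CC1` differs from compound 2 by furan-2-yl in place of 4-methylphenyl on an aromatic carbon. Going by the values given here, no measured step bears on this change, and the one measured step is itself unreadable, so nothing in the numbers points to a step in this assay beyond the scatter in either direction. Compound 3 is therefore expected to sit near the limit as well, at about 200 ug/mL, between 100 ug/mL and 400 ug/mL. The step that the limit leaves unreadable from compound 2 to compound 3 that this estimate implies is expected to lie within the scatter.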

Compound 3, half-maximal inhibitory concentration: > 150 ug/mL
Compound 3: no number, only a limit; the forecaster's own chance of this, stated with the estimate: 80%; the middle value does not contradict the limit.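

Compound 3 gives only a limit in this assay, so no step among compound 1, compound 2 and compound 3 can be read in size or direction: the limit of > 150 ug/mL in this assay, at which 3 of the 3 values shown sit.

The compounds shown leave open what number each of the three would reach in this assay, and whether the changes among them have any effect there.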